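Moving the methoxy group: from acetyl back to methoxy

The source may hold more compounds than are shown below. What is called first, only, known or untested is meant among the compounds shown, and "the series" means these compounds.

Measured compounds:
compound 1 `COc1ccc(-c2cn3ccnc3c(-c3ccc4ncn(C5CCCCC5)c4c3)n2)cc1`: 87.2%
compound 2 `CC(=O)c1ccc(-c2cn3ccnc3c(-c3ccc4ncn(C5CCCCC5)c4c3)n2)cc1`: 4.17%

Of the two compounds measured in a functional assay on NCI/ADR-RES cells (Homo sapiens) for inhibition, read by sulforhodamine B assay, with a stated time of 48 h, tested at 10 uM (on this read-out higher numbers stand for more inhibition at the one concentration tested (going by the name of the read-out) and lower numbers for less inhibition), compound 2 stands lowest, with compound 1 the nearest and far higher, since a number 83 percentage points lower from compound 1 to compound 2 (beyond the scatter). Compound 3 `COc1ccccc1-c1cn2ccnc2c(-c2ccc3ncn(C4CCCCC4)c3c2)n1` has not yet been measured; it differs from compound 2 as follows: 2-methoxyphenyl in place of 4-acetylphenyl on an aromatic carbon. Going by the values given here, the only step that bears on this change is the one from compound 1 to compound 2, where acetyl took the place of methoxy and inhibition fell by a number 83 percentage points lower from compound 1 to compound 2 (beyond the scatter). Among the compounds with values here, compound 3 reverses that exchange, carrying methoxy again, though the methoxy group now sits as 2-methoxyphenyl rather than as in compound 1, and no measured pair shows what that placement does. A large rise in this assay is therefore expected, of about a number 60.8 percentage points higher from compound 2 to compound 3 (beyond the scatter), with wide uncertainty. Compound 3 is estimated at 65%, between 25% and 95%.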

Compound 3, a percentage reported as inhibition, at one concentration (the size of the read-out at that concentration, not a potency): 0.06%
Compound 3: the middle estimate sits 64.9 percentage points above what was measured; measured number outside the range, below it.
By their numbers in this assay, from the lowest: compounds 3 and 2 (each within the scatter of the next); then compound 1.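

In this assay, the methoxy group alone does not carry the inhibition of compound 1: 2-methoxyphenyl in place of 4-methoxyphenyl gives a number 87.1 percentage points lower from compound 1 to compound 3 (beyond the scatter), so at this position the result depends on where the methoxy group sits on the phenyl ring. Going by these compounds alone, exchanging 4-acetylphenyl for 2-methoxyphenyl gives a number 4.1 percentage points lower from compound 2 to compound 3 (within the scatter), so these two groups cannot be told apart here, and of the three compounds only the one with 4-methoxyphenyl shows high inhibition. The data shown offer no measurement that explains this difference.

From the compounds shown here alone, it remains open whether an amine, a hydroxyl group or a longer chain such as ethoxy in place of the methoxy of the 4-methoxyphenyl group would keep the inhibition. Going by these compounds, it also remains open whether the same order would hold at other concentrations or in other cells.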